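Three-substituted phenylpiperazine succinimides in the electroshock model

A few compounds are considered here, and "the series" means these few. Any claim that something is new, unique, unknown or untested is made for them only; others in the source may bear on it.

For the measured compounds named here, compound 2 `CCC(C(=O)N1CCN(c2cccc(C)c2)CC1)N1C(=O)CCC1=O` stands lowest of the two numbers so far: in a functional assay on the whole organism (strain Swiss) with Mus musculus as the target, in the maximal electroshock model, with a stated time of 2 h, at a dose of 300 mg/kg by the intraperitoneal route (on this read-out lower numbers stand for a weaker effect and higher numbers for a stronger effect at the one dose given), compound 2 gives 0%, while compound 1 `CCC(C(=O)N1CCN(c2cccc(C(F)(F)F)c2)CC1)N1C(=O)CCC1=O` gives 50%. Going by the values given here, the one measured step, a number 50 percentage points lower from compound 1 to compound 2 (beyond the scatter), is the only one bearing on the next change, and only partly, since here methyl is the group that leaves. Compound 3 `CCC(C(=O)N1CCN(c2cccc(Cl)c2)CC1)N1C(=O)CCC1=O` differs from compound 2 by chloro in place of methyl on an aromatic carbon. A rise of a number 25 percentage points higher from compound 2 to compound 3 (beyond the scatter) is expected, well short of the drop seen in a number 50 percentage points lower from compound 1 to compound 2 (beyond the scatter). Compound 3 is therefore estimated at 25%, within a range of 0% to 55%.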

Compound 3, a percentage reported as activity, at one dose (the size of the read-out at that dose, not a potency): 25%
For compound 3 middle estimate and measured number coincide at the digits printed; the range from low to high includes it.
By their numbers in this assay, from the lowest: compound 2; then compound 3; then compound 1.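

Chloro at this position gives an intermediate reading in this assay, with a number 25 percentage points higher from compound 2 to compound 3 (beyond the scatter) and a number 25 percentage points lower from compound 1 to compound 3 (beyond the scatter). The three groups on this aromatic carbon are now separated beyond the scatter, in the order trifluoromethyl, chloro, methyl, a ranking that holds for these three compounds only. Nothing available here accounts for that order.

On these data alone, whether a nitrile, a methoxy group or an amine on the same carbon would fit this order remains open. Also open, as far as these compounds go, is whether the order would hold at a different dose.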